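Acyl pyrazole in place of the diacylhydrazide

This account rests on a few compounds, and the source may have more. Where it says the series, first, only, none or still open, it means among the compounds named here.

The series shares the core of compound 1 `CCOC(=O)C1=C(C)NC(C)=C(C(=O)OCC)C1c1ccc(OCC(=O)NNC(=O)c2ccc(C)cc2)cc1` and compound 2 `CCOC(=O)C1=C(C)NC(C)=C(C(=O)OCC)C1c1ccc(OCC(=O)NNC(=O)c2cccs2)cc1`. In a functional assay on the whole organism (strain Wistar) for inhibition, with Rattus norvegicus as the target, read by paw edema, with stated times of 30 min and 1 h, at a dose of 20 mg/kg (on this read-out higher numbers stand for more inhibition at the one dose given (going by the name of the read-out) and lower numbers for less inhibition), compound 1 gives 35.9% and compound 2 gives 55.1%. Within the data shown here, the single measured step, a number 19.2 percentage points higher from compound 1 to compound 2 (beyond the scatter), is the change thiophen-2-yl in place of 4-methylphenyl on a carbonyl carbon. Among the measured compounds shown here, compound 2 therefore stands highest of the two numbers, with compound 1 as its only neighbour, lower by that step.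

Compound 3 `CCOC(=O)C1=C(C)NC(C)=C(C(=O)OCC)C1c1ccc(OCC(=O)n2nc(C)cc2C)cc1` is not yet measured in this assay. It differs from compound 2 by 3,5-dimethyl-1H-pyrazol-1-yl in place of (((thiophen-2-yl)carbonyl)amino)amino on a carbonyl carbon. The measured step exchanged one aromatic group for another while keeping the (((thiophen-2-yl)carbonyl)amino)amino link; here that whole link leaves and 3,5-dimethyl-1H-pyrazol-1-yl enters directly on the carbonyl carbon whose other neighbour is a saturated chain carbon. For the measured compounds named here, no measured pair covers such a change; a number 19.2 percentage points higher from compound 1 to compound 2 (beyond the scatter) shows only that the group on this carbonyl can move the read-out beyond the scatter. The step of a number 10.1 percentage points lower from compound 2 to compound 3 (beyond the scatter) is thus expected to be small and uncertain in direction, with a wide range. Compound 3 is estimated at 45%, range 20% to 70%.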

Compound 3, a percentage reported as inhibition, in the whole organism at one dose (the size of the read-out at that dose, not a potency): 32.7%
Compound 3: middle estimate off by 12.3 percentage points, on the high side; the measured number falls inside the stated range.
By their numbers in this assay, from the lowest: compounds 3 and 1 (each within the scatter of the next); then compound 2.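

In this assay, 3,5-dimethyl-1H-pyrazol-1-yl in place of (((thiophen-2-yl)carbonyl)amino)amino on the carbonyl carbon gives a number 22.4 percentage points lower from compound 2 to compound 3 (beyond the scatter), the first sign that exchanging the whole link, and not just its aromatic group, can move the read-out beyond the scatter. The same replacement starting from the 4-methylphenyl member gives a number 3.2 percentage points lower from compound 1 to compound 3 (within the scatter), so the two steps differ in outcome: the cost of the exchange appears only against the thiophen-2-yl link, and the (((4-methylphenyl)carbonyl)amino)amino link holds no measurable advantage over the pyrazole. No measurement on these compounds bears on the reason for this difference.

The link and the aromatic group at its end remain hard to separate, and a furan-2-yl or an unsubstituted phenyl on the same link would test whether the higher number is particular to thiophen-2-yl. A morpholine amide or a free carboxylic acid on this carbonyl carbon would show whether a value at the level of compound 2 can be reached without the link, and whether 3,5-dimethyl-1H-pyrazol-1-yl behaves differently from other groups placed directly there.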